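The source may report more compounds than this note shows. Statements on the series, on what has been measured and on what is new or still open speak of the compounds shown alone.

Compound 1 `COc1ccc(/C=C(/C(=O)c2cc(OC)c(OC)c(OC)c2)c2ccccc2O)cc1` is the parent of this small set; in a functional assay on K562 cells (Homo sapiens) for antiproliferative activity, read by MTT assay, with a stated time of 5 days (a lower number here means a stronger inhibitor, a higher number a weaker inhibitor), compound 1 gives 370000 nM. Among the measured compounds shown here, it stands second highest of the three numbers: compound 3 `COc1ccc(/C=C(/C(=O)c2cc(OC)c(OC)c(OC)c2)c2ccccc2O)cc1O[Si](C)(C)C(C)(C)C` gives 380000 nM, within the scatter of compound 1, while compound 2 `COc1ccc(/C=C(/C(=O)c2cc(OC)c(OC)c(OC)c2)c2ccccc2O)cc1F` gives 60000 nM, the only clearly stronger member, the step being a 6.2-fold lower number from compound 1 to compound 2 (0.79 log units; beyond the scatter). The remaining step, a 6.3-fold higher number from compound 2 to compound 3 (0.80 log units; beyond the scatter), mirrors this.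

Compound 4 `COc1ccc(/C=C(/C(=O)c2cc(OC)c(OC)c(OC)c2)c2ccccc2)cc1` differs from compound 1 by hydrogen in place of hydroxy on an aromatic carbon. For the measured compounds named here, none of the measured steps bears directly on it: all three vary a different aromatic carbon, and no pair shows the hydroxy removed. Going by the values given here, the modest spread seen so far, with only one substitution moving the number beyond the scatter, suggests this exchange is more likely to leave the value in the same weak region than to shift it strongly. Compound 4 is therefore expected to give about 400000 nM, with 150000 nM to 1000000 nM as its range, meaning an estimated step of a 1.1-fold higher number from compound 1 to compound 4 (0.03 log units; within the scatter).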

Compound 4, half-maximal inhibitory concentration: 20000 nM
Beside the measured number, compound 4's estimate is 20-fold (1.30 log units) above it; the measured number lies below the stated range.
By their numbers in this assay, from the lowest: compound 4; then compound 2; then compounds 1 and 3 (each within the scatter of the next).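

In this assay, among the compounds shown here, the change from 2-hydroxyphenyl to phenyl gives a 19-fold lower number from compound 1 to compound 4 (1.27 log units; beyond the scatter) and is the largest step read so far. For the compounds shown here, it is also the first reading at this position, on an aromatic carbon ortho to a large group, since the earlier steps varied a different aromatic carbon. The hydroxy is therefore not required for activity on this core, and hydrogen in its place gives a clearly stronger compound, though no measurement on hand accounts for the step.

From the compounds shown here alone, it remains open how a methoxy, an amine or a carboxylic acid would read at this carbon, and so whether hydrogen is the best group here. Going by these compounds, it is also open whether the gain seen with fluoro at the other aromatic carbon would add to this one on the phenyl compound.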